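Three Measured Analogues and an Expected Fourth

This account rests on a few compounds, and the source may have more. Where it says the series, first, only, none or still open, it means among the compounds named here.

In a functional assay on CHO cells with adenosine receptor A1 (Homo sapiens) as the target, read by cAMP accumulation and immunoassay, with a stated time of 6 min, tested at 1 uM (a lower number here means a stronger effect, a higher number a weaker effect of the compound at the concentration tested), the three measured compounds gave the following:
compound 1 `Nc1scc(CN2CCN(c3cc(Cl)cc(Cl)c3)CC2)c1C(=O)c1ccc(Cl)cc1`: -69%
compound 2 `Nc1scc(CN2CCN(c3ccc(Cl)cc3F)CC2)c1C(=O)c1ccc(Cl)cc1`: -57%
compound 3 `Nc1scc(CN2CCN(c3c(F)cccc3F)CC2)c1C(=O)c1ccc(Cl)cc1`: -65%

Compound 1 stands lowest of the three in this assay; compound 3 lies nearest, and compound 2 furthest. Compound 4 `Nc1scc(CN2CCN(c3cc(F)ccc3F)CC2)c1C(=O)c1ccc(Cl)cc1` differs from compound 1 by one change: 2,5-difluorophenyl in place of 3,5-dichlorophenyl on an amine nitrogen in a ring. Among the compounds with values here, two measured steps bear on this exchange of the group on the ring nitrogen. The step of a number 12 percentage points higher from compound 1 to compound 2 (beyond the scatter) was modest, while a number 4 percentage points higher from compound 1 to compound 3 (within the scatter) stayed within the scatter. Both replacements of the 3,5-dichlorophenyl left the number the same or somewhat higher, so a small upward step is expected for compound 4, a number 7 percentage points higher from compound 1 to compound 4 (within the scatter). The expected value for compound 4 is therefore -62%, with a range from -73% to -49%.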

Compound 4, a percentage reported as activity, at one concentration (the size of the read-out at that concentration, not a potency): -59%
Beside the measured number, compound 4's estimate is 3 percentage points below it, and the stated range covers the measured number.
By their numbers in this assay, from the lowest: compounds 1, 3, 4 and 2 (each within the scatter of the next, the first and the last beyond it).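

In this assay, the 2,5-difluorophenyl group can't be told apart from any of the three earlier groups on the ring nitrogen (a number 10 percentage points higher from compound 1 to compound 4 (within the scatter); a number 6 percentage points higher from compound 3 to compound 4 (within the scatter); a number 2 percentage points lower from compound 2 to compound 4 (within the scatter)). Compound 4 therefore falls within the scatter of both compound 1 and compound 2, even though those two differ by more than the scatter. Nothing available here explains these numbers. From the compounds shown here alone, all four groups are halogenated phenyl rings, so it remains open how an unsubstituted phenyl, a methoxyphenyl or a pyridine ring would behave at this position.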